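Adding a Chlorine to a Cyclohexyl Enone Ester

This account rests on a few compounds, and the source may have more. Where it says the series, first, only, none or still open, it means among the compounds named here.

Compound 1, `O=C(/C(=C/c1ccc(Cl)cc1)CCl)c1ccccc1`, and compound 2, `O=C(/C(=C/c1ccc(Cl)cc1Cl)CCl)c1ccccc1`, share one core and differ only by chloro in place of hydrogen on an aromatic carbon. In a functional assay on HeLa cells (Homo sapiens) for inhibition, read by sulforhodamine B assay, with a stated time of 48 h (on this read-out higher numbers stand for weaker inhibition of growth and lower numbers for stronger inhibition of growth), compound 1 gives 22000 nM, and compound 2 gives 15000 nM. The step of a 1.5-fold lower number from compound 1 to compound 2 (0.17 log units; within the scatter) is too small to count as a real shift in growth inhibition. Compound 3, `CC(=O)OC/C(=C\C1CCCCC1)C(=O)c1ccccc1`, rests on another core; how the two cores differ is not broken down here. In this assay compound 3 gives 21000 nM, a number that sits among those of compound 1 and compound 2 within the usual spread of repeated measurements.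

Compound 4, `CC(=O)OC/C(=C\C1CCCCC1)C(=O)c1ccc(Cl)cc1`, has not yet been measured. It differs from compound 3 by chloro in place of hydrogen on an aromatic carbon. Among the compounds with values here, this is the same kind of change as the one from compound 1 to compound 2, but the surroundings differ: in compound 4 the entering chloro sits para to a large group, whereas in compound 2 it sits ortho to a large group and meta to a chloro group.

Within the data shown here, the only measured example of this kind of change, a 1.5-fold lower number from compound 1 to compound 2 (0.17 log units; within the scatter), stayed within the scatter, so the estimated step for the new pair is likewise small, a 1.2-fold lower number from compound 3 to compound 4 (0.09 log units; within the scatter). The two cores are different, which leaves room for the step to come out somewhat larger or smaller than before. In this assay compound 4 is expected to give 17000 nM, with a likely range from 8000 nM to 38000 nM.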

Compound 4, concentration for 50% growth inhibition: 24000 nM
Estimate against measurement, compound 4: 1.4-fold (0.15 log units) below; the measured number falls inside the stated range.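

In this assay, chloro in place of hydrogen on an aromatic carbon gives a 1.1-fold higher number from compound 3 to compound 4 (0.06 log units; within the scatter), so on this core too the step is too small to count as a real shift in growth inhibition. Set side by side, the steps on the two cores do not differ by more than repeated measurements would be expected to: the same change on two cores in this assay, a 1.5-fold lower number (0.17 log units; within the scatter) from compound 1 to compound 2 and a 1.1-fold higher number (0.06 log units; within the scatter) from compound 3 to compound 4, 1.7-fold (0.22 log units) apart, within the scatter of two such steps. Within the data shown here, this shows that the change had no readable effect on either core, but it rests on only two pairs with the chloro in different surroundings, and two steps lost in the scatter cannot show that a real effect of this change would carry from one core to another.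

The compounds shown leave open whether a different group on the same aromatic carbon, such as a methoxy group, an amine or a carboxylic acid, would move the number beyond the scatter on either core. They also leave open what would happen if the cyclohexyl group of compound 3 gave way to a longer chain, or if its acetate ester gave way to an amine, and whether the chloro would then matter any more than it does here.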